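A few compounds are considered here, and "the series" means these few. Any claim that something is new, unique, unknown or untested is made for them only; others in the source may bear on it.

Measured in a functional assay on HCT-116 cells (Homo sapiens) for inhibition, read by MTT assay, with a stated time of 2 days; on this read-out higher numbers stand for lower toxicity in this test and lower numbers for higher toxicity in this test:
- compound 1 `Nc1ccccc1NC(=O)CCCNCC(=O)Nc1cccc(Cl)c1`: > 100000 nM (a limit)
- compound 2 `Nc1ccccc1NC(=O)c1ccc(NCC(=O)Nc2ccc([N+](=O)[O-])cc2)cc1`: > 100000 nM (a limit)
- compound 3 `Nc1ccccc1NC(=O)CCCNCC(=O)Nc1ccccc1Cl`: > 100000 nM (a limit)

Compound 2 stands at > 100000 nM, which is a limit of the assay and not a number. No order among the measured compounds can be read because of the limit of > 100000 nM in this assay, at which 3 of the 3 values shown sit.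

The next compound is compound 4 `Cc1ccc(NC(=O)CNc2ccc(C(=O)Nc3ccccc3N)cc2)cc1`, which differs from compound 2 as follows: methyl in place of nitro on an aromatic carbon. In words, this is methyl in place of nitro on an aromatic carbon, para to a large group, so 4-nitrophenyl becomes 4-methylphenyl.

Going by the values given here, the only measured step is a step that the two limits leave unreadable from compound 1 to compound 3. Among the compounds with values here, it concerns a different change and offers no size to carry over, and no measured step involves nitro or methyl. Within the data shown here, with only that unreadable step to go on, no step beyond the scatter is expected in this assay, and no direction can be assigned. The expectation rests mainly on compound 2, whose > 100000 nM is a limit.

The estimated step is a number no higher from compound 2 to compound 4 (the limit leaves the size open). Another report as a limit is the likeliest expected outcome. For compound 4 the estimate is 100000 nM, with an expected range from 30000 nM to 200000 nM.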

Compound 4, concentration lethal to 50% of the cells: > 100000 nM
Compound 4 ended at the assay's limit; the forecaster's own chance of this, stated with the estimate: 70%; the middle value sits exactly at the limit.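

In this assay no new step can be read from compound 2 to compound 4, since both values are limits and not numbers: the limit of > 100000 nM in this assay, at which 4 of the 4 values shown sit.

The compounds shown leave open how 4-nitrophenyl and 4-methylphenyl compare, and which change, if any, would bring a value in this series to a readable number.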